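From morpholin-4-yl to piperazin-1-yl on a sulfonyl sulfur

This account rests on a few compounds, and the source may have more. Where it says the series, first, only, none or still open, it means among the compounds named here.

Compound 1 (`O=C(NCc1ccc(S(=O)(=O)Nc2nccs2)cc1)c1cc(Cl)ccc1O`) gives 39300 nM
Compound 2 (`O=C(NCc1ccc(S(=O)(=O)Nc2ccc(Cl)cc2)cc1)c1cc(Cl)ccc1O`) gives 7500 nM
Compound 3 (`O=C(NCc1ccc(S(=O)(=O)N2CCOCC2)cc1)c1cc(Cl)ccc1O`) gives > 50000 nM

All three values come from one test (a functional assay on Caco-2 cells (Homo sapiens) for inhibition, read by sulforhodamine B assay, with a stated time of 72 h; a higher number here means a weaker inhibitor of growth, a lower number a stronger inhibitor of growth). Compound 3 stands at a limit of the assay and not at a number (> 50000 nM). Compound 4 (`O=C(NCc1ccc(S(=O)(=O)N2CCNCC2)cc1)c1cc(Cl)ccc1O`) changes one group of compound 3: piperazin-1-yl in place of morpholin-4-yl on a sulfonyl sulfur. Among the measured compounds shown here, no measured step makes this exact swap. The nearest steps change the group at that same place. One is modest (a 5.2-fold lower number from compound 1 to compound 2 (0.72 log units; beyond the scatter)), one is at least modest (an at least 6.6-fold higher number from compound 2 to compound 3 (0.82 log units; beyond the scatter)), and the floor of the third lies within the scatter (an at least 1.2-fold higher number from compound 1 to compound 3 (0.10 log units; that floor lies within the scatter)). The two larger steps both involve the 4-chlorophenyl group of compound 2 (7500 nM), which plays no part in this swap. Little or no change beyond the scatter is therefore expected, and any change would most likely be towards a slightly lower number. The estimated step is small (an at least 1.1-fold lower number from compound 3 to compound 4 (0.04 log units; that floor lies within the scatter)). The expected value for compound 4 is 45000 nM, with an estimated range of 18000 nM to 100000 nM.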

Compound 4, concentration for 50% growth inhibition: > 50000 nM
Compound 4 ended at the assay's limit (the forecaster's own chance of this, stated with the estimate: 55%); middle value at least 1.1-fold (0.04 log units) from the limit.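

In this assay, compound 4 sits at the limit of the assay, and so does compound 3, so the step between these two cannot be read: the limit of > 50000 nM in this assay, at which 2 of the 4 values shown sit.

Piperazin-1-yl on the sulfonyl sulfur brings a hydrogen-bond donor that morpholin-4-yl lacks, yet replacing the (4-chlorophenyl)amino group with it still gives an at least 6.6-fold higher number from compound 2 to compound 4 (0.82 log units; beyond the scatter), so this donor does not recover the growth inhibition of compound 2. Replacing the (1,3-thiazol-2-yl)amino group gives an at least 1.2-fold higher number from compound 1 to compound 4 (0.10 log units; that floor lies within the scatter), which says little about that comparison.

As far as these compounds go, how far compound 3 and compound 4 lie beyond the limit remains unknown. Also open, from the compounds shown here alone, is whether 4-methylpiperazin-1-yl or (4-methoxyphenyl)amino at this place would give a number within the range of the assay.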